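Ethyl, tert-butyl and nitro on the outer ring, trifluoromethyl next

This account rests on a few compounds, and the source may have more. Where it says the series, first, only, none or still open, it means among the compounds named here.

Three compounds share one core and differ only in the substituent on the outer benzamide ring: compound 1 `CCc1ccc(C(=O)Nc2cccc(NC(=O)COc3ccc4c(=O)ccoc4c3)c2)cc1`, compound 2 `CC(C)(C)c1ccc(C(=O)Nc2cccc(NC(=O)COc3ccc4c(=O)ccoc4c3)c2)cc1` and compound 3 `O=C(COc1ccc2c(=O)ccoc2c1)Nc1cccc(NC(=O)c2ccc([N+](=O)[O-])cc2)c1`. In an assay on isolated protein for inhibition of Rho-associated protein kinase 2 (Homo sapiens), read by scintillation counting, radiometric assay and 33P incorporation, with a stated time of 40 min, in the presence of a further agent that is not named here (on this read-out lower numbers stand for stronger inhibition and higher numbers for weaker inhibition), compound 1 gives 24 nM, compound 2 gives 34 nM and compound 3 gives 15 nM. Compound 3 carries the lowest number of the three, though the gap to compound 1 stays within the scatter, while a 2.3-fold lower number from compound 2 to compound 3 (0.36 log units; beyond the scatter) is beyond it. Compound 4 `Cc1cc(C(=O)Nc2cccc(NC(=O)COc3ccc4c(=O)ccoc4c3)c2)ccc1C(F)(F)F` replaces the nitro-bearing ring: a group of 11 heavy atoms (8 carbon, 3 fluorine; one six-membered aromatic ring of carbon only) in place of a group of 9 heavy atoms (6 carbon, 1 nitrogen, 2 oxygen; one six-membered aromatic ring of carbon only), on a carbonyl carbon. Going by the values given here, the steps that bear on this are a 1.6-fold lower number from compound 1 to compound 3 (0.20 log units; within the scatter) and a 2.3-fold lower number from compound 2 to compound 3 (0.36 log units; beyond the scatter); both moves away from nitro toward a carbon-only substituent gave higher numbers, one within and one beyond the scatter. Compound 4 is therefore expected to give a higher number than compound 3, about a 2.0-fold higher number from compound 3 to compound 4 (0.30 log units; within the scatter) in this assay. The estimate for compound 4 is 30 nM, with a range from 12 nM to 75 nM.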

Compound 4, half-maximal inhibitory concentration: 43 nM
Estimate against measurement, compound 4: 1.4-fold (0.16 log units) below, within the range that was stated.
By their numbers in this assay, from the lowest: compounds 3, 1, 2 and 4 (each within the scatter of the next, the first and the last beyond it).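

In this assay there is a 2.9-fold higher number from compound 3 to compound 4 (0.46 log units; beyond the scatter) and this is a second move away from nitro that lands beyond the scatter, so compound 3 now stands apart from both compound 2 and compound 4. Fluorine on the ring does not set compound 4 apart from the carbon-only substituents, with a 1.3-fold higher number from compound 2 to compound 4 (0.10 log units; within the scatter) and with a 1.8-fold higher number from compound 1 to compound 4 (0.25 log units; within the scatter) as well. No measurement shown bears on the reason for these steps.

As far as these compounds go, compound 4 carries methyl and trifluoromethyl together, so their separate contributions stay open. From the compounds shown here alone, what an amine or a carboxylic acid on the outer ring would give also stays open.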